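The compounds below may be only part of what the source reports. "The series", "measured", "known", "first", "only" and "open" are said of these compounds alone.

Of the compounds shown here, three have been measured in a functional assay for agonist activity at Bombesin receptor subtype-3 (Homo sapiens); on this read-out higher numbers stand for an effect only at larger amounts of compound and lower numbers for an effect already at smaller amounts. Compound 1, `c1ccc(-c2nnn[nH]2)c(-c2ccc(CCc3nc(CC4CCCC4)c[nH]3)cc2)c1`, gives 56 nM in this assay. Compound 2, `O=C1NC(=O)C(c2ccccc2-c2ccc(CCC3N=CC(CC4CCCC4)=N3)cc2)S1`, gives 1770 nM. Compound 3, `CCC(C)(C)Cc1c[nH]c(CCc2ccc(-c3ccccc3OCc3ncn[nH]3)cc2)n1`, gives 172 nM, which places it second highest of the three numbers; the nearest number is that of compound 1, which lies below it by more than the usual scatter, and the furthest is that of compound 2, which lies above it by a wide margin that is also beyond the scatter.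

Compound 4, `CCC(C)(C)Cc1c[nH]c(CCc2ccc(-c3ccccc3OCc3cnn[nH]3)cc2)n1`, has not been measured. It differs from compound 3 in one place: 1H-1,2,3-triazol-5-yl in place of 1H-1,2,4-triazol-5-yl on a saturated chain carbon bound to an oxygen on an aromatic ring. The two compounds share every atom and differ only in how the ring atoms are joined. For the measured compounds named here, no pair of measured compounds shows such a change, so the size of its effect has no precedent here. Given that, the step from compound 3 to compound 4 in this assay is expected to be small, a 1.2-fold higher number from compound 3 to compound 4 (0.07 log units; within the scatter), with no direction beyond the scatter clearly favored. The value of compound 4 in this assay is estimated at 200 nM, with a range from 80 nM to 500 nM.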

Compound 4, half-maximal effective concentration: 399 nM
For compound 4 the middle estimate is 2.0-fold (0.30 log units) below the measured one; the range from low to high includes it.
By their numbers in this assay, from the lowest: compound 1; then compound 3; then compound 4; then compound 2.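

In this assay, placing 1H-1,2,3-triazol-5-yl in place of 1H-1,2,4-triazol-5-yl on a saturated chain carbon bound to an oxygen on an aromatic ring gives a 2.3-fold higher number from compound 3 to compound 4 (0.37 log units; beyond the scatter), a modest step. This position therefore registers how the ring atoms are joined, even though the two groups have the same heavy atoms, the same counts of hydrogen-bond donors and acceptors, and no net charge. Nothing in the information at hand accounts for this step. This single pair leaves open whether the same exchange would give a step of similar size and direction on the core of compound 1, which carries a different side chain. It also leaves open how a carboxylic acid or a primary amine would fare on that same saturated chain carbon.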